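This account rests on a few compounds, and the source may have more. Where it says the series, first, only, none or still open, it means among the compounds named here.

Measured so far in a functional assay on BGC-823 cells (Homo sapiens) for antiproliferative activity, read by MTT assay, tested at 5 uM; a higher number here means a stronger effect of the compound at the concentration tested, a lower number a weaker effect:
compound 1 `COc1cc(C(=O)N/N=C/c2ccc(F)c(F)c2)cc(OC)c1OC`: 51.9%
compound 2 `COc1cc(C(=O)N/N=C/c2cccc(F)c2)cc(OC)c1OC`: 44.8%
compound 3 `COc1ccc(C2OC(c3cc(OC)c(OC)c(OC)c3)=NN2C(C)=O)c(OC)c1`: -3.1%

Compound 3 stands lowest of the three numbers. Its nearest neighbour is compound 2, and the gap to it lies beyond the scatter; the gap to compound 1 is wider still. Compound 3 carries the cyclised core with an acetyl group on the ring nitrogen, whereas compound 1 and compound 2 carry the open hydrazone core.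

Compound 4 `COc1cc(C2=NN(C(C)=O)C(c3ccc(F)c(F)c3)O2)cc(OC)c1OC` keeps the core of compound 3. The change is 3,4-difluorophenyl in place of 2,4-dimethoxyphenyl on a saturated ring carbon.

Among the measured compounds shown here, only one measured step exists, a number 7.1 percentage points lower from compound 1 to compound 2 (within the scatter), and it concerns a fluoro on the open core, not the exchange of one aryl group for another on the saturated ring carbon. For the measured compounds named here, no measured step bears directly on the present change. What the numbers do show is that the 3,4-difluorophenyl group sits in compound 1, the highest value in this assay, while the cyclised core of compound 3 gives the lowest. The expectation for the step from compound 3 to compound 4 is therefore a modest rise, a number 13.1 percentage points higher from compound 3 to compound 4 (beyond the scatter), with wide uncertainty. Compound 4 is estimated at 10%, in the range -8% to 35%.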

Compound 4, a percentage reported as inhibition, at one concentration (the size of the read-out at that concentration, not a potency): 21.6%
For compound 4 the middle estimate is 11.6 percentage points below the measured one; the measured number falls inside the stated range.
By their numbers in this assay, from the lowest: compound 3; then compound 4; then compounds 2 and 1 (each within the scatter of the next).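

In this assay, among the compounds shown here, the first measured step at the saturated ring carbon of this core is a number 24.7 percentage points higher from compound 3 to compound 4 (beyond the scatter), so the read-out responds to the aryl group there, next to the ring nitrogen and the ring oxygen, even with the acetyl group and the trimethoxyphenyl side unchanged. For the compounds shown here, the only earlier step concerned a fluoro on the open core and lay within the scatter, so this exchange is the first change to move the number beyond it. The exchange replaces 2,4-dimethoxyphenyl, with 10 heavy atoms and 2 hydrogen-bond acceptors, by 3,4-difluorophenyl, with 8 heavy atoms and 0 hydrogen-bond acceptors, and no available measurement explains the rise or separates the contributions of these differences.

Still open, going by these compounds, is whether the rise follows from losing the methoxy groups, gaining the fluoro groups or both, which a plain phenyl or a 3-fluorophenyl at this carbon would help to separate. Also open, on these data alone, is how this position would respond to an aryl group carrying a dimethylamino group or a carboxylic acid, and whether a propanoyl group in place of the acetyl group would shift the read-out.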